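Hydrazine nitrogen methylation in the NF-kappa-B series

This account rests on a few compounds, and the source may have more. Where it says the series, first, only, none or still open, it means among the compounds named here.

Compound 1 `CCOC(=O)c1cnc(-c2ccccc2)nc1NN1C(=O)C=C(C)C1=O` is the reference point of this set. In a functional assay on Jurkat cells for inhibition of nuclear factor NF-kappa-B complex (Homo sapiens) (on this read-out higher numbers stand for weaker inhibition and lower numbers for stronger inhibition), compound 1 gives 100 nM. Compound 2 `CCOC(=O)c1cnc(-c2ccsc2)nc1NN1C(=O)C=C(C)C1=O` gives 100 nM in this assay, and compound 3 `CCOC(=O)c1cnc(Sc2ccccc2)nc1NN1C(=O)C=C(C)C1=O` gives 1000 nM. Compound 1 thus stands level with compound 2 and together they hold the lowest number of the three; the step of no change at the digits printed from compound 1 to compound 2 (within the scatter) and the step of a 10-fold higher number from compound 1 to compound 3 (1.00 log units; beyond the scatter) define where compound 1 sits, with the step of a 10-fold higher number from compound 2 to compound 3 (1.00 log units; beyond the scatter) of the same size as the latter.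

Compound 4 `CCOC(=O)c1cnc(-c2ccccc2)nc1N(C)N1C(=O)C=C(C)C1=O` differs from compound 1 by methyl in place of hydrogen on a nitrogen on an aromatic ring. Going by the values given here, none of the measured steps touches this position: all three vary the aryl group on an aromatic carbon and leave the nitrogen in question untouched. Among the compounds with values here, there is therefore no measured step that bears on this change, and no direction can be read from the set. The expectation for compound 4 is a step of a 1.5-fold higher number from compound 1 to compound 4 (0.18 log units; within the scatter) of no size beyond the scatter, with a wide range. Compound 4 is estimated at 150 nM, between 40 nM and 800 nM.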

Compound 4, half-maximal inhibitory concentration: 2000 nM
Estimate against measurement, compound 4: 13-fold (1.12 log units) below; the measured number lies above the stated range.
By their numbers in this assay, from the lowest: compounds 1 and 2 (each within the scatter of the next); then compounds 3 and 4 (each within the scatter of the next).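

On this nitrogen, methyl in place of hydrogen is not a neutral change: in this assay it gives a 20-fold higher number from compound 1 to compound 4 (1.30 log units; beyond the scatter), a large step beyond the scatter and towards weaker inhibition. Going by these compounds alone, the earlier compounds varied only the group on the aromatic carbon, so this is the first sign that activity also depends on the nitrogen carrying a hydrogen rather than a methyl. Nothing at hand bears on the reason for this loss.

The compounds shown pair methyl on this nitrogen only with phenyl, so it remains open whether a step of this size would also hold with thiophen-3-yl or phenylsulfanyl. Also open, on these data alone, is how an ethyl, an acetyl or a longer chain on this nitrogen would read out.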